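Nitro substitution on two cores, one measured, one pending

This account rests on a few compounds, and the source may have more. Where it says the series, first, only, none or still open, it means among the compounds named here.

Measured so far:
Compound 1 `CC1=NN(Cc2nc3ccccc3[nH]2)C(=O)C1`: in a functional assay on MCF7 cells (Homo sapiens) for cytotoxicity, read by MTT assay (on this read-out lower numbers stand for stronger inhibition and higher numbers for weaker inhibition), compound 1 gives 62000 nM.
Compound 2 `O=[N+]([O-])c1ccc2[nH]c(CNc3nc4ccc(F)cc4s3)nc2c1`: in this assay compound 2 gives 291000 nM.
Compound 3 `Fc1ccc2nc(NCc3nc4ccccc4[nH]3)sc2c1`: in this assay compound 3 gives 242000 nM.

Compound 1 holds the lowest of the three numbers, and both other compounds stand beyond the scatter above it. Among the compounds with values here, the only measured pair that differs in one place is compound 3 and compound 2: nitro in place of hydrogen on an aromatic carbon. The step is a 1.2-fold higher number from compound 3 to compound 2 (0.08 log units; within the scatter). The difference between the core of compound 1 and the core of compound 3 is not broken down here.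

Compound 4 `CC1=NN(Cc2nc3cc([N+](=O)[O-])ccc3[nH]2)C(=O)C1` is not yet measured. Within the data shown here, it differs from compound 1 by nitro in place of hydrogen on an aromatic carbon, the same change as the one from compound 3 to compound 2, at the same place. For compound 4 the expected step is a 1.2-fold higher number from compound 1 to compound 4 (0.08 log units; within the scatter), a small one, because a 1.2-fold higher number from compound 3 to compound 2 (0.08 log units; within the scatter) on the other core. That single instance sits on a different core, so the range is kept wide. Compound 4 is estimated at 75000 nM, expected between 30000 nM and 190000 nM.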

Compound 4, half-maximal inhibitory concentration: 281000 nM
Compound 4: middle estimate off by 3.7-fold (0.57 log units), on the low side; measured number above the stated range.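

In this assay, nitro in place of hydrogen on an aromatic carbon gives a 4.5-fold higher number from compound 1 to compound 4 (0.66 log units; beyond the scatter), which is a modest step and one beyond the scatter. The size of this step therefore does not carry over from one core to the other in this series: the same change on two cores in this assay, a 1.2-fold higher number (0.08 log units; within the scatter) from compound 3 to compound 2 and a 4.5-fold higher number (0.66 log units; beyond the scatter) from compound 1 to compound 4, 3.8-fold (0.58 log units) apart, beyond the scatter of two such steps

These two pairs show only that the outcome of this change depends on the core it sits on; they do not show which feature of the cores sets the gap, and with a single pair on each core they give no general rule for other cores.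

The compounds shown leave open whether an amine or a nitrile on the same aromatic carbon would also give steps that differ between the two cores. They also leave open whether nitro on another carbon of that six-membered aromatic ring would give a step like the one on the core of compound 1 or one like that on the core of compound 3.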